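Trading the hydroxy of an ester side chain for methyl

A few compounds are considered here, and "the series" means these few. Any claim that something is new, unique, unknown or untested is made for them only; others in the source may bear on it.

Three compounds share one core and differ only in the alcohol part of an ester. Compound 1 `NCc1ccc(C(=O)Nc2ccncc2F)cc1-c1cccc(C(=O)Oc2ccccc2)c1` carries a phenyl there and gives 6.2 nM in an assay on isolated protein for inhibition of Rho-associated protein kinase 2 (Homo sapiens), read by radiometric assay; on this read-out lower numbers stand for stronger inhibition and higher numbers for weaker inhibition. Compound 2 `NCc1ccc(C(=O)Nc2ccncc2F)cc1-c1cccc(C(=O)OCC2CCCO2)c1` gives 2.5 nM in this assay, and compound 3 `NCc1ccc(C(=O)Nc2ccncc2F)cc1-c1cccc(C(=O)OCCO)c1` gives 1.4 nM. Compound 3 has the lowest number of the three: the larger gap is a 4.4-fold lower number from compound 1 to compound 3 (0.65 log units; beyond the scatter), while the smaller gap is a 1.8-fold lower number from compound 2 to compound 3 (0.25 log units; within the scatter), so compound 3 and compound 2 cannot be told apart.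

Compound 4 `CCCOC(=O)c1cccc(-c2cc(C(=O)Nc3ccncc3F)ccc2CN)c1` differs from compound 3 by methyl in place of hydroxy on a saturated chain carbon, two bonds along the chain from an oxygen next to a carbonyl group. Within the data shown here, no measured step removes a hydroxy in quite this way. The step of a 1.8-fold lower number from compound 2 to compound 3 (0.25 log units; within the scatter) shows that changing the chain end while keeping an oxygen there hardly moves the number, and a 2.5-fold lower number from compound 1 to compound 2 (0.39 log units; beyond the scatter) shows the alcohol part can shift the number modestly. A small rise in number is expected for compound 4, a 2.1-fold higher number from compound 3 to compound 4 (0.33 log units; beyond the scatter), possibly within the scatter. Compound 4 is therefore estimated at 3 nM, between 1.2 nM and 7.5 nM.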

Compound 4, half-maximal inhibitory concentration: 5.1 nM
Compound 4: middle estimate off by 1.7-fold (0.23 log units), on the low side; the measured number falls inside the stated range.
By their numbers in this assay, from the lowest: compounds 3 and 2 (each within the scatter of the next); then compounds 4 and 1 (each within the scatter of the next).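

Among these compounds, of the steps so far, only this one changes nothing but the chain end: hydroxy gives way to methyl and, in this assay, the result is a step beyond the scatter (a 3.6-fold higher number from compound 3 to compound 4 (0.56 log units; beyond the scatter)). Ethyl in place of oxolan-2-yl also gives a step beyond the scatter (a 2.0-fold higher number from compound 2 to compound 4 (0.31 log units; beyond the scatter)), while propyl in place of phenyl stays within it (a 1.2-fold lower number from compound 1 to compound 4 (0.08 log units; within the scatter)), so among these four compounds the two alcohol parts with an oxygen in the chain end have the lower numbers, with no compound going against this. Nothing measured here explains this difference.

As far as these compounds go, it remains open whether an amine or a carboxylic acid at the chain end would match hydroxy. A longer chain ending in hydroxy, or a methoxy end, is equally untested among the compounds shown.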